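A few compounds are considered here, and "the series" means these few. Any claim that something is new, unique, unknown or untested is made for them only; others in the source may bear on it.

Of the compounds shown here, three built on one shared core have been tested in a functional assay on MCF7 cells (Homo sapiens) for antiproliferative activity, read by sulforhodamine B assay, with a stated time of 48 h; a lower number here means a stronger inhibitor, a higher number a weaker inhibitor. Compound 1 `CCCCCc1ccc(NS(=O)(=O)c2ccc(N3CCNC3=O)cc2)cc1` carries a pentyl group on an aromatic carbon; in this assay compound 1 reaches only a limit of the assay, > 1000 nM. Compound 2 `CCc1ccccc1NS(=O)(=O)c1ccc(N2CCNC2=O)cc1` carries a 2-ethylphenyl on the sulfonamide nitrogen and gives a measured number, 350 nM. Compound 3 `COc1ccc(NS(=O)(=O)c2ccc(N3CCNC3=O)cc2)cc1` carries a 4-methoxyphenyl on the sulfonamide nitrogen; in this assay compound 3 likewise gives only a limit of the assay, > 1000 nM. Compound 3 thus sits at the edge of what the assay can report: the limit of > 1000 nM in this assay, at which 2 of the 3 values shown sit. The change an at least 2.8-fold higher number from compound 2 to compound 3 (0.45 log units; beyond the scatter) lies beyond the scatter, whereas a step that the two limits leave unreadable from compound 1 to compound 3 cannot be sized.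

Compound 4 `O=C1NCCN1c1ccc(S(=O)(=O)Nc2ccc(OC(F)F)cc2)cc1` differs from compound 3 in a single place: difluoromethyl in place of methyl on an oxygen on an aromatic ring. Neither measured step touches this oxygen; both concern the groups on the aromatic carbon or on the sulfonamide nitrogen. Among the measured compounds shown here, no measured step therefore gives a direction, and with compound 3 already at a limit, another limit is the likelier outcome. Compound 4 is expected to give about 2000 nM, within 600 nM to 7000 nM. The expected step is a step that the limit leaves unreadable from compound 3 to compound 4, and it remains to be seen what the assay reports.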

Compound 4, half-maximal inhibitory concentration: 760 nM
For compound 4 the middle estimate is 2.6-fold (0.42 log units) above the measured one; measured number inside the range.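

With difluoromethyl in place of methyl on this oxygen, compound 4 gives a true measured number in this assay, so a compound with a substituted oxygen at this place can be read directly rather than only as a limit. The change of methoxy to difluoromethoxy is an at least 1.3-fold lower number from compound 3 to compound 4 (0.11 log units; that floor lies within the scatter), and the change from the pentyl group is an at least 1.3-fold lower number from compound 1 to compound 4 (0.11 log units; that floor lies within the scatter). Both figures are only floors, so the two steps may be larger or may be no real change, and their true size stays hidden because compound 1 and compound 3 each stand at a limit and not at a number: the limit of > 1000 nM in this assay, at which 2 of the 4 values shown sit.

The compounds shown therefore do not settle whether adding fluorine on this oxygen truly lowers the number, since a single pair with one limit cannot separate a real gain from ordinary scatter. Also open, as far as these compounds go, is what other groups on this oxygen would give, such as a trifluoromethyl, a longer chain like propyl, or a chain ending in an amine or a carboxylic acid.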